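The source may hold more compounds than are shown below. What is called first, only, known or untested is meant among the compounds shown, and "the series" means these compounds.

Of the compounds shown here, three sharing one core have been measured in an ADME assay on GES1 cells (Homo sapiens) for inhibition, read by MTT assay, with a stated time of 72 h; on this read-out higher numbers stand for weaker inhibition and lower numbers for stronger inhibition: compound 1 (`Cc1cc(Nc2cc(-c3ccccc3)[nH]n2)n2nc(SCc3ccc(F)cc3)nc2n1`) gives 35500 nM, compound 2 (`Cc1cc(Nc2cc(-c3ccccc3)[nH]n2)n2nc(SCc3ccccc3Br)nc2n1`) gives 41100 nM, and compound 3 (`Cc1cc(Nc2cc(-c3ccccc3)[nH]n2)n2nc(SCc3cccc4ccccc34)nc2n1`) gives 36300 nM. Compound 3 thus stands within the scatter of both others. The unmeasured compound 4 (`Cc1cc(Nc2cc(-c3ccccc3)[nH]n2)n2nc(SCC3CC3)nc2n1`) carries cyclopropyl in place of naphthalen-1-yl on a saturated chain carbon bound to a sulfur. For the measured compounds named here, three measured steps bear on this place: a 1.2-fold higher number from compound 1 to compound 2 (0.06 log units; within the scatter), a 1.0-fold higher number from compound 1 to compound 3 (0.01 log units; within the scatter) and a 1.1-fold lower number from compound 2 to compound 3 (0.05 log units; within the scatter). All of them stay within the scatter, so swapping one aromatic group for another has made no measurable difference in this small set. None of these steps brings in a non-aromatic ring, however, so they reach the present change only indirectly, and the range must stay wide. No shift beyond the scatter is expected, and the estimated step is a 1.2-fold higher number from compound 3 to compound 4 (0.06 log units; within the scatter). Compound 4 is estimated at 42000 nM, with an expected range from 20000 nM to 90000 nM.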

Compound 4, half-maximal inhibitory concentration: > 50000 nM
Compound 4: a limit, no number (the forecaster's own chance of this, stated with the estimate: 15%); middle value at least 1.1-fold (0.07 log units) from the limit.
By their numbers in this assay, from the lowest: compounds 1, 3 and 2 (each within the scatter of the next). At a limit, above all of these: compound 4.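

In this assay compound 4 gives a limit and not a number: the limit of > 50000 nM in this assay, at which 1 of the 4 values shown sits. For the compounds shown here, with cyclopropyl, a non-aromatic ring enters this place on a saturated chain carbon bound to a sulfur for the first time, and the steps read an at least 1.3-fold higher number from compound 3 to compound 4 (0.13 log units; that floor lies within the scatter), an at least 1.2-fold higher number from compound 2 to compound 4 (0.08 log units; that floor lies within the scatter) and an at least 1.4-fold higher number from compound 1 to compound 4 (0.14 log units; that floor lies within the scatter). Going by these compounds alone, the earlier compounds showed only one aromatic group exchanged for another, whereas this change shows that going from an aromatic group to this much smaller ring brings no stronger inhibition, though each floor leaves open whether the number truly moved.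

As far as these compounds go, how far compound 4 lies from the other three remains unknown, since its reading stops at a limit. The compounds shown also leave open how an amine, a carboxylic acid or a longer alkyl chain would read at this place.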